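The compounds below may be only part of what the source reports. "The series", "measured", "known", "first", "only" and "open" are said of these compounds alone.

Compound 1 `CSc1ccc(NC(=O)Nc2cc(C)nc3ccccc23)cc1` was examined in an ADME assay on HepG2 cells (Homo sapiens) for cytotoxicity, with a stated time of 72 h (on this read-out lower numbers stand for an effect already at smaller amounts and higher numbers for an effect only at larger amounts of compound), where compound 1 gives 16000 nM. Compound 3 `Cc1cc(NC(=O)Nc2ccc(C(N)=O)cc2)c2ccccc2n1` reaches only a limit of the assay, > 25000 nM. That change, (carbamoyl in place of methylsulfanyl on an aromatic carbon), brings an at least 1.5-fold higher number from compound 1 to compound 3 (0.19 log units; that floor lies within the scatter). Compound 2 `CSc1ccccc1NC(=O)Nc1cc(C)nc2ccccc12` is built from the same atoms as compound 1, but the difference between the two cores is not broken down here. In this assay compound 2 likewise sits at a limit, > 25000 nM. Compound 4 `Cc1cc(NC(=O)Nc2ccccc2C(N)=O)c2ccccc2n1` has not yet been measured; it carries carbamoyl in place of methylsulfanyl on an aromatic carbon, though here the group sits ortho to a large group rather than para, so this is the same kind of change as before, not the same. Beside an at least 1.5-fold higher number from compound 1 to compound 3 (0.19 log units; that floor lies within the scatter), the step from compound 2 to compound 4 is expected to be a step that the limit leaves unreadable from compound 2 to compound 4, a cautious guess because compound 2 already rests at the limit of > 25000 nM in this assay, at which 2 of the 3 values shown sit. Compound 4 is therefore estimated at 30000 nM in this assay, between 15000 nM and 80000 nM, most likely reported only as a limit.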

Compound 4, half-maximal effective concentration: > 25000 nM
Compound 4: no number, only a limit; the forecaster's own chance of this, stated with the estimate: 75%; the middle value is on the limit's open side.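

Compound 2 and compound 4 both rest at a limit in this assay, so no step between them can be read: the limit of > 25000 nM in this assay, at which 3 of the 4 values shown sit.

The compounds shown leave open whether carbamoyl in place of methylsulfanyl changes this read-out at all when ortho to a large group.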